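Benzylpiperidine amide series: piperazinyl change, cytotoxicity outlook

This account rests on a few compounds, and the source may have more. Where it says the series, first, only, none or still open, it means among the compounds named here.

Measured so far in a functional assay on SV5A8 cells (Homo sapiens) for cytotoxicity; a higher number here means a weaker inhibitor, a lower number a stronger inhibitor:
Compound 1 `Cc1ccc2c(NCc3ccc(NC(=O)C4CCN(Cc5ccccc5)CC4)cc3)nc(N(C)CCCN(C)C)nc2c1` gives only a limit, > 8620 nM.
Compound 2 `Cc1ccc2c(NCc3ccc(NC(=O)C4CCN(Cc5ccccc5)CC4)cc3)nc(N(C)CCN(C)C)nc2c1` gives only a limit, > 8830 nM.
Compound 3 `CCNc1nc(NCc2ccc(NC(=O)C3CCN(Cc4ccccc4)CC3)cc2)c2ccc(C)cc2n1` gives only a limit, > 2140 nM.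

Compound 3 stands at one of three limits; none of the three measured compounds returns a number in this assay, so no order among them can be read. The steps among them, a step that the two limits leave unreadable from compound 1 to compound 2, a step that the two limits leave unreadable from compound 1 to compound 3 and a step that the two limits leave unreadable from compound 2 to compound 3, are each unreadable, both ends sitting at limits.

Compound 4 `Cc1ccc2c(NCc3ccc(NC(=O)C4CCN(Cc5ccccc5)CC4)cc3)nc(N3CCN(C)CC3)nc2c1` differs from compound 3 in one place: 4-methylpiperazin-1-yl in place of ethylamino on an aromatic carbon. Among the measured compounds shown here, no measured step bears directly on this change; the three that exist are unreadable and concern other groups on the same aromatic carbon. The expectation for compound 4 rests only on the three limits in this assay. The step that the limit leaves unreadable from compound 3 to compound 4 is estimated to be none beyond the scatter. Compound 4 is expected to return a limit as well, estimated at 10000 nM, range 3000 nM to 40000 nM.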

Compound 4, half-maximal inhibitory concentration: > 17700 nM
Compound 4 ended at the assay's limit; the forecaster's own chance of this, stated with the estimate: 75%; middle value at least 1.7-fold (0.24 log units) from the limit.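

In this assay compound 4 gives only a limit, > 17700 nM. Among the compounds shown here, compound 1, compound 2 and compound 3 also stand at limits, so no step to compound 4 can be read. The compounds shown leave open whether changing this aromatic-carbon group alters cytotoxicity at all.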